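Shortening the sulfur-linked chain from compound 3 to compound 4

The source may report more compounds than this note shows. Statements on the series, on what has been measured and on what is new or still open speak of the compounds shown alone.

Compound 1 `CCCCSc1n[nH]c(-n2[se]c3ccccc3c2=O)n1` gives 30400 nM in an ADME assay on L929 cells (Mus musculus) for antiproliferative activity, read by CCK-8 assay, with a stated time of 48 h; a higher number here means a weaker inhibitor, a lower number a stronger inhibitor. Compound 2 `Cc1ccccc1CSc1n[nH]c(-n2[se]c3ccccc3c2=O)n1` gives 15600 nM in this assay. Compound 3 `Cc1ccc(CSc2n[nH]c(-n3[se]c4ccccc4c3=O)n2)cc1` gives > 50000 nM in this assay, which is a limit of the assay rather than a number, as shown by the limit of > 50000 nM in this assay, at which 1 of the 3 values shown sits. Compound 4 `CCCSc1n[nH]c(-n2[se]c3ccccc3c2=O)n1` differs from compound 3 in one place: ethyl in place of 4-methylphenyl on a saturated chain carbon bound to a sulfur. Among the measured compounds shown here, two measured steps bear on this change, both running into compound 3: an at least 1.6-fold higher number from compound 1 to compound 3 (0.21 log units; that floor lies within the scatter), and an at least 3.2-fold higher number from compound 2 to compound 3 (0.50 log units; beyond the scatter). Compound 4 carries a short chain much like compound 1 with its 30400 nM, so a return toward that number is expected. The expected step is an at least 1.6-fold lower number from compound 3 to compound 4 (0.22 log units; that floor lies within the scatter), toward a lower number. Compound 4 is therefore estimated at 30000 nM, ranging from 12000 nM to 80000 nM.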

Compound 4, half-maximal inhibitory concentration: 31800 nM
Compound 4: the middle estimate sits 1.1-fold (0.03 log units) below what was measured; the range from low to high includes it.
By their numbers in this assay, from the lowest: compounds 2, 1 and 4 (each within the scatter of the next, the first and the last beyond it). At a limit, above all of these: compound 3.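

Among the short straight chains, the length hardly registers (a 1.0-fold higher number from compound 1 to compound 4 (0.02 log units; within the scatter)). The short chain now stands clearly apart from the 2-methylphenyl group (a 2.0-fold higher number from compound 2 to compound 4 (0.31 log units; beyond the scatter)), a separation that compound 1 alone did not show. The step away from the 4-methylphenyl group (an at least 1.5-fold lower number from compound 3 to compound 4 (0.19 log units; that floor lies within the scatter)) gives only a floor because its starting value is a limit of the assay: the limit of > 50000 nM in this assay, at which 1 of the 4 values shown sits.

From the compounds shown here alone, whether a longer chain or an amine at this place would move the number stays open. Going by these compounds, the true value of compound 3 also remains unknown.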